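Replacing (1,3-benzothiazol-2-yl)sulfanyl with 1H-indol-1-yl

This account rests on a few compounds, and the source may have more. Where it says the series, first, only, none or still open, it means among the compounds named here.

Of the compounds shown here, three sharing one core have been measured in a functional assay on PC-3 cells (Homo sapiens) for antiproliferative activity, read by MTT assay, with a stated time of 48 h; on this read-out higher numbers stand for weaker inhibition and lower numbers for stronger inhibition. Compound 2 `COc1ccc(CN(C(=O)Cn2cc(CSc3nc4ccccc4s3)nn2)c2cc(OC)c(OC)c(OC)c2)cc1` gives 28500 nM and compound 3 `COc1ccc(CN(C(=O)Cn2cc(CSc3nnc(-c4ccccc4)c(-c4ccccc4)n3)nn2)c2cc(OC)c(OC)c(OC)c2)cc1` gives 19600 nM, two values within the scatter of each other. Compound 1 `COc1ccc(CN(C(=O)Cn2cc(COc3ccc4c(C)cc(=O)oc4c3)nn2)c2cc(OC)c(OC)c(OC)c2)cc1` gives 340 nM, so compound 2 stands far above it on this scale, among the weaker inhibitors of this small set together with compound 3.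

Compound 4 `COc1ccc(CN(C(=O)Cn2cc(Cn3ccc4ccccc43)nn2)c2cc(OC)c(OC)c(OC)c2)cc1` has not yet been measured. It differs from compound 2 by one exchange: 1H-indol-1-yl in place of (1,3-benzothiazol-2-yl)sulfanyl on a saturated chain carbon bound to an aromatic carbon. Here 1H-indol-1-yl replaces (1,3-benzothiazol-2-yl)sulfanyl on a saturated chain carbon bound to an aromatic carbon. Among the measured compounds shown here, no measured pair isolates this change, so only the spread of the three values can guide the expectation. Like compound 4, compound 1 carries no sulfur, and it reaches 340 nM, while both sulfur-bearing compounds stay far higher. A moderate move towards stronger inhibition is expected, though a result within the scatter of compound 2 remains possible. The expected change is a 4.8-fold lower number from compound 2 to compound 4 (0.68 log units; beyond the scatter). For compound 4 the estimated value is 6000 nM, with an expected range of 1200 nM to 28000 nM.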

Compound 4, half-maximal inhibitory concentration: 2390 nM
Estimate against measurement, compound 4: 2.5-fold (0.40 log units) above; the range from low to high includes it.
By their numbers in this assay, from the lowest: compound 1; then compound 4; then compounds 3 and 2 (each within the scatter of the next).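

In this assay, among the compounds shown here, 1H-indol-1-yl in place of (1,3-benzothiazol-2-yl)sulfanyl gives a 12-fold lower number from compound 2 to compound 4 (1.08 log units; beyond the scatter), and this is the first measured pair that isolates a single change on this saturated chain carbon bound to an aromatic carbon. For the compounds shown here, it shows that inhibition here is sensitive to the group at this place, which the earlier compounds could not show without such a pair. Nothing available explains the size of this step.

The exchange alters the sulfanyl link and the fused ring together, so the compounds shown do not separate the contribution of each. They also leave open how 1,3-benzothiazol-2-yl without the sulfanyl link, a longer chain carrying 1H-indol-1-yl, or an amine such as morpholin-4-yl would behave at this place.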